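Swapping the aryl group on the hydrazone of compound 2

A few compounds are considered here, and "the series" means these few. Any claim that something is new, unique, unknown or untested is made for them only; others in the source may bear on it.

Measured compounds:
- compound 1 `Cc1cc(Cl)ccc1Nc1nc(C(F)(F)F)ccc1C(=O)N/N=C/c1ccc(N(C)C)cc1`: 66100 nM
- compound 2 `Cc1cc(Cl)ccc1Nc1nc(C(F)(F)F)ccc1C(=O)N/N=C/c1ccc(F)cc1`: 7080 nM
- compound 3 `Cc1cc(Cl)ccc1Nc1nc(C(F)(F)F)ccc1C(=O)N/N=C/c1cccc(O)c1`: 11000 nM

In a functional assay on NCI60 cells (Homo sapiens) for cytotoxicity, read by sulforhodamine B assay, with a stated time of 48 h (a higher number here means a weaker inhibitor of growth, a lower number a stronger inhibitor of growth), compound 2 gives the lowest of the three numbers. Its nearest neighbour is compound 3, with a 1.6-fold higher number from compound 2 to compound 3 (0.19 log units; within the scatter); its furthest is compound 1, with a 9.3-fold lower number from compound 1 to compound 2 (0.97 log units; beyond the scatter). The new compound 4 `Cc1cc(Cl)ccc1Nc1nc(C(F)(F)F)ccc1C(=O)N/N=C/c1c(Cl)cccc1Cl` keeps the shared core of compound 2 and changes only the aryl group on the hydrazone: 2,6-dichlorophenyl in place of 4-fluorophenyl on a carbon with a double bond to nitrogen.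

Within the data shown here, no measured step covers a 2,6-dichlorophenyl group, so the expectation rests on the surrounding changes. Moving from compound 1 to compound 2 and to compound 3 gave modest steps, a 9.3-fold lower number from compound 1 to compound 2 (0.97 log units; beyond the scatter) and a 6.0-fold lower number from compound 1 to compound 3 (0.78 log units; beyond the scatter), while the swap between a 4-fluorophenyl and a 3-hydroxyphenyl group stayed within the scatter, a 1.6-fold higher number from compound 2 to compound 3 (0.19 log units; within the scatter). Two aryl groups without dimethylamino gave similar numbers, so for compound 4 the expected step is a 1.2-fold lower number from compound 2 to compound 4 (0.07 log units; within the scatter), within the scatter. Compound 4 is therefore estimated at 6000 nM, with a range from 2000 nM to 20000 nM.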

Compound 4, concentration for total growth inhibition: 11700 nM
For compound 4 the middle estimate is 2.0-fold (0.29 log units) below the measured one, and the stated range covers the measured number.
By their numbers in this assay, from the lowest: compounds 2, 3 and 4 (each within the scatter of the next); then compound 1.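

In this assay, a ring carrying two chlorines and no fluorine or hydroxyl still lands level with the other aryl groups lacking dimethylamino, with a 1.7-fold higher number from compound 2 to compound 4 (0.22 log units; within the scatter) and a 1.1-fold higher number from compound 3 to compound 4 (0.03 log units; within the scatter). Compound 1 alone stands apart, with a 5.6-fold lower number from compound 1 to compound 4 (0.75 log units; beyond the scatter), so three quite different aryl groups on this carbon now give similar numbers, and only the 4-(dimethylamino)phenyl group goes against that pattern. No supporting measurement is available to explain this pattern.

The compounds shown leave open whether a saturated ring such as cyclohexyl, or a phenyl ring carrying a carboxylic acid, would stay at the same level. They also leave open whether a primary amine on the ring would give a number as high as that of compound 1.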